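A few compounds are considered here, and "the series" means these few. Any claim that something is new, unique, unknown or untested is made for them only; others in the source may bear on it.

The study starts from compound 1 `O=Cc1cn(-c2ccccc2)nc1-c1ccc(Cl)cc1`. In a functional assay on MCF7 cells (Homo sapiens) for antiproliferative activity, read by MTT assay, with a stated time of 24 h, tested at 0.001 ug/mL (on this read-out higher numbers stand for a weaker effect at the one concentration tested and lower numbers for a stronger effect), compound 1 gives 98%, a reading that amounts to practically no effect at the single low concentration tested. The far larger compound 2 `COc1cc(/C=C/C(=O)C(=Cc2cn(-c3ccccc3)nc2-c2ccc([N+](=O)[O-])cc2)C(=O)/C=C/c2ccc(O)c(OC)c2)ccc1O` is the second measured member of the set. In this assay compound 2 gives 98%, which stands level with compound 1 at the digits recorded, the two readings lying within the usual scatter of each other. For the measured compounds named here, no pair of measured compounds differing in only one place is available, so how a single change moves the read-out has not been mapped. Compound 3 `COc1cc(/C=C/C(=O)C(=Cc2cn(-c3ccccc3)nc2-c2ccccc2O)C(=O)/C=C/c2ccc(O)c(OC)c2)ccc1O` is the unmeasured member. It differs from compound 2 in one place: 2-hydroxyphenyl in place of 4-nitrophenyl on an aromatic carbon. With both measured compounds sitting at the same reading and nothing in the data to suggest that a change at this position shifts the read-out, the expected step is a number 1 percentage points lower from compound 2 to compound 3 (within the scatter), none beyond the scatter. Compound 3 is therefore estimated to give 97% in this assay, with a range from 87% to 104%.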

Compound 3, a percentage reported as activity, at one concentration (the size of the read-out at that concentration, not a potency): 97%
Estimate against measurement, compound 3: no gap at the digits printed, within the range that was stated.
By their numbers in this assay, from the lowest: compounds 3, 1 and 2 (each within the scatter of the next).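

In this assay, for the compounds shown here, putting 2-hydroxyphenyl in place of 4-nitrophenyl on this aromatic carbon of the five-membered ring gives a number 1 percentage points lower from compound 2 to compound 3 (within the scatter), and this is the first step that can be read at a single place. It shows that this exchange, which trades a group of 9 heavy atoms with no hydrogen-bond donor for one of 7 heavy atoms with 1 hydrogen-bond donor, does not move the reading beyond the scatter at the one low concentration tested. No measurement that could explain this result is available.

From the compounds shown here alone, what remains open is whether an unsubstituted phenyl, an aminophenyl or a carboxyphenyl at this same position would move the reading beyond the scatter, and whether a hydroxyl group placed elsewhere on the phenyl ring would read any differently from 2-hydroxyphenyl. Going by these compounds alone, also open is whether compound 2 and compound 3 would still read alike at higher concentrations, since a single low concentration gives no potency for either compound.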